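This account rests on a few compounds, and the source may have more. Where it says the series, first, only, none or still open, it means among the compounds named here.

Two compounds measured in a functional assay on A549 cells (Homo sapiens) for inhibition, read by sulforhodamine B assay, with a stated time of 48 h (a lower number here means a stronger inhibitor of growth, a higher number a weaker inhibitor of growth), define the starting point. Compound 1 `COC(=O)[C@@]1(C)CCC=C2[C@@H]1CC[C@@H](C)[C@]2(C)Cc1c(C)[nH]c2ccc(OC)cc12` gives 16000 nM in this assay, and compound 2 `COC(=O)[C@@]1(C)CC[C@@H]2C3=C1CC[C@@H](C)[C@]3(C)C[C@@H]1c3cc(C)ccc3N[C@H]21` gives 27000 nM. Compound 2 holds the higher of the two numbers, but the two values lie within the usual scatter of each other, so no order can be read from them. Compound 3 `COC(=O)[C@@]1(C)CC[C@@H]2C3=C1CC[C@@H](C)[C@]3(C)C[C@@H]1c3cc(F)ccc3N[C@H]21` is the next compound and has not yet been measured. It differs from compound 2 in one place: fluoro in place of methyl on an aromatic carbon. Among the measured compounds shown here, no measured pair in this set carries that change, so there is no earlier step to lean on. A change of this kind is expected to move this assay only a little, if at all beyond the scatter, in either direction. Compound 3 is therefore estimated at 25000 nM, with a range from 10000 nM to 60000 nM. The estimate means a step of a 1.1-fold lower number from compound 2 to compound 3 (0.03 log units; within the scatter), expected to stay within the scatter.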

Compound 3, concentration for 50% growth inhibition: 25000 nM
For compound 3 middle estimate and measured number coincide at the digits printed; the range from low to high includes it.
By their numbers in this assay, from the lowest: compounds 1, 3 and 2 (each within the scatter of the next).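

In this assay, fluoro in place of methyl on the aromatic carbon gives a 1.1-fold lower number from compound 2 to compound 3 (0.03 log units; within the scatter). Among the compounds shown here, this is the first measured step at this position, which is meta to a fused ring and para to a fused ring, and it shows that the read-out does not separate these two single-atom groups here. Nothing at hand gives a reason for this result or tests one.

The compounds shown carry only methyl and fluoro at this aromatic carbon, so it remains open whether a group such as an amine, a carboxylic acid or a longer chain there would give a step beyond the scatter. Whether any change at this position can move this assay at all also remains unanswered.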